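A few compounds are considered here, and "the series" means these few. Any claim that something is new, unique, unknown or untested is made for them only; others in the source may bear on it.

Working notes on a short series tested in a functional assay on NCI/ADR-RES cells (Homo sapiens) for inhibition, read by sulforhodamine B assay, with a stated time of 48 h; a higher number here means a weaker inhibitor of growth, a lower number a stronger inhibitor of growth.

Compound 1 `CC1(/C=C/c2ccccc2O)C=CC(=O)O1` gives 78000 nM in this assay. Compound 2 `CC1(/C=C/c2ccc(O)cc2)C=CC(=O)O1` carries the same atoms joined differently; the difference between the two cores is not broken down here. In this assay compound 2 gives 111000 nM, a number within the scatter of compound 1. Compound 3 `COc1ccccc1/C=C/C1(C)C=CC(=O)O1` differs from compound 1 by methyl in place of hydrogen on an oxygen on an aromatic ring, and in this assay compound 3 gives 64500 nM; the step is a 1.2-fold lower number from compound 1 to compound 3 (0.08 log units; within the scatter).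

Compound 4 `COc1ccc(/C=C/C2(C)C=CC(=O)O2)cc1` differs from compound 2 by methyl in place of hydrogen on an oxygen on an aromatic ring, the same kind of change as from compound 1 to compound 3, made on the core of compound 2. Among the compounds with values here, only one such step has been measured, so the expectation rests on compound 2 at 111000 nM and on the step of a 1.2-fold lower number from compound 1 to compound 3 (0.08 log units; within the scatter) alone. The step is expected to be a 1.2-fold lower number from compound 2 to compound 4 (0.09 log units; within the scatter), and compound 4 is estimated at 90000 nM, between 45000 nM and 180000 nM.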

Compound 4, concentration for total growth inhibition: > 1000000 nM
Compound 4 was reported as a limit (the forecaster's own chance of this, stated with the estimate: 20%); middle value at least 11-fold (1.04 log units) from the limit.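

Carrying hydroxy to methoxy from one core to the other does not preserve the step in this assay: the same change on two cores in this assay, a 1.2-fold lower number (0.08 log units; within the scatter) from compound 1 to compound 3 and an at least 9.0-fold higher number (0.95 log units; beyond the scatter) from compound 2 to compound 4, at least 10-fold (1.03 log units) apart, beyond the scatter of two such steps. As far as these compounds go, compound 4 is reported only as a limit, > 1000000 nM, not as a number, so the full size of its step stays unknown: the limit of > 1000000 nM in this assay, at which 1 of the 4 values shown sits. The change gives an at least 9.0-fold higher number from compound 2 to compound 4 (0.95 log units; beyond the scatter), which shows that its outcome differs between these two cores, but not why it differs or what it would do on a further core.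

Left open is how a longer chain such as ethyl on that oxygen would read on either core. Also open, from the compounds shown here alone, is how an amine or a carboxylic acid in place of the hydroxy would read.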